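Working notes: aryl group change from compound 3 to compound 4

The source may hold more compounds than are shown below. What is called first, only, known or untested is meant among the compounds shown, and "the series" means these compounds.

In an in vitro ADME assay on microsomes from liver (Homo sapiens) for pharmacokinetics, read by LC-MS, with a stated time of 10 min, tested at 1 uM (a lower number here means slower removal, a higher number faster removal of the compound), compound 1 `COc1ccc(NC(=O)[C@H]2CN(C)C[C@@H]2c2ccc(/C=C/C(=O)Nc3ccccc3N)cc2)cc1` gives 14 mL/min/kg, compound 2 `CN1C[C@H](C(=O)Nc2ccc(C(F)(F)F)cc2)[C@@H](c2ccc(/C=C/C(=O)Nc3ccccc3N)cc2)C1` gives 6 mL/min/kg and compound 3 `CN1C[C@H](C(=O)Nc2ccccc2F)[C@@H](c2ccc(/C=C/C(=O)Nc3ccccc3N)cc2)C1` gives 10 mL/min/kg. Compound 3 therefore stands within the scatter of both others, and its number cannot be ranked against theirs.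

Compound 4 `CN1C[C@H](C(=O)Nc2ccc(F)c(Cl)c2)[C@@H](c2ccc(/C=C/C(=O)Nc3ccccc3N)cc2)C1` keeps the shared core and differs on the amide-type nitrogen: 3-chloro-4-fluorophenyl in place of 2-fluorophenyl on an amide-type nitrogen. In words, 3-chloro-4-fluorophenyl replaces 2-fluorophenyl. All three measured steps change the group at this same place, so all three bear on the new one. Two stay within the scatter: a 1.4-fold lower number from compound 1 to compound 3 (0.15 log units; within the scatter) and a 1.7-fold higher number from compound 2 to compound 3 (0.22 log units; within the scatter). The largest, a 2.3-fold lower number from compound 1 to compound 2 (0.37 log units; beyond the scatter), is only modest. Within the data shown here, no measured compound carries chlorine, so the series gives no direct reading for that atom, and no direction can be argued from these steps.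

The expected change is a 1.1-fold lower number from compound 3 to compound 4 (0.05 log units; within the scatter), which means no expected step beyond the scatter. For compound 4 the estimated clearance is 9 mL/min/kg, with an expected range of 5 mL/min/kg to 17 mL/min/kg.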

Compound 4, clearance: 15 mL/min/kg
The estimate for compound 4 lay 1.7-fold (0.22 log units) below the measured number, and the stated range covers the measured number.
By their numbers in this assay, from the lowest: compounds 2, 3, 1 and 4 (each within the scatter of the next, the first and the last beyond it).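

In this assay, among these compounds, the first group with chlorine on the amide-type nitrogen, 3-chloro-4-fluorophenyl, gives a 1.5-fold higher number from compound 3 to compound 4 (0.18 log units; within the scatter) and a 1.1-fold higher number from compound 1 to compound 4 (0.03 log units; within the scatter), so it cannot be told apart from 2-fluorophenyl or 4-methoxyphenyl. Among the compounds shown here, the only new step beyond the scatter is a 2.5-fold higher number from compound 2 to compound 4 (0.40 log units; beyond the scatter), which joins a 2.3-fold lower number from compound 1 to compound 2 (0.37 log units; beyond the scatter), so 4-(trifluoromethyl)phenyl now stands apart from two groups, though still not from 2-fluorophenyl, as compound 3 stays within the scatter of compound 2. Nothing at hand explains any of these steps.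

Still open, on these data alone, is whether chlorine or fluorine contributes to the reading for compound 4, which a phenyl group carrying chlorine alone would test. Also open, as far as these compounds go, is how a carboxylic acid or an amine on the aryl group, or a saturated alkyl chain in its place, would read at this nitrogen.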